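From Methyl to Phenylsulfanyl on a Shared Core

A few compounds are considered here, and "the series" means these few. Any claim that something is new, unique, unknown or untested is made for them only; others in the source may bear on it.

Three compounds sharing one core, and differing in the group on a single aromatic carbon, have been measured in a physicochemical assay for lipophilicity; a lower number here means a more polar compound, a higher number a more lipophilic compound. Compound 1 `COc1c(OC)c(OC(C)=O)c2c(Cl)cccc2c1OC(C)=O`, carrying chloro, gives 3.16. Compound 2 `COc1c(OC)c(OC(C)=O)c2c(NC(C)=O)cccc2c1OC(C)=O`, carrying acetamido, gives 2. Compound 3 `COc1c(OC)c(OC(C)=O)c2c(C)cccc2c1OC(C)=O`, carrying methyl, gives 2.8, the second highest of the three numbers.

Compound 4 `COc1c(OC)c(OC(C)=O)c2c(Sc3ccccc3)cccc2c1OC(C)=O` has not yet been measured. It carries phenylsulfanyl in place of methyl on an aromatic carbon.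

All three measured steps swap the group on this same carbon. Methyl in place of chloro gives a number 0.36 log units lower from compound 1 to compound 3 (beyond the scatter), and methyl in place of acetamido gives a number 0.80 log units higher from compound 2 to compound 3 (beyond the scatter). Both are modest. Acetamido in place of chloro gives a number 1.16 log units lower from compound 1 to compound 2 (beyond the scatter), which is large. None of these steps involves phenylsulfanyl, so the data offer no direct measure of it.

For the measured compounds named here, the expectation in this assay is therefore a judgement: a large step upward, comparable in size to the one that separates compound 2 from compound 1 at 3.16, but starting from methyl. The estimated step is a number 1.40 log units higher from compound 3 to compound 4 (beyond the scatter). The estimate for compound 4 is 4.2, with an expected range from 3.6 to 4.8.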

Compound 4, partition coefficient: 4.2
The estimate for compound 4 equals the measured number at the digits printed; measured number inside the range.
By their numbers in this assay, from the lowest: compound 2; then compound 3; then compound 1; then compound 4.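

In this assay, phenylsulfanyl takes this aromatic carbon beyond anything the earlier groups reached: the change from methyl gives a number 1.40 log units higher from compound 3 to compound 4 (beyond the scatter), and the change from chloro gives a number 1.04 log units higher from compound 1 to compound 4 (beyond the scatter), so chloro no longer marks the top of the series and compound 4 stands highest of the four. The span across this one position also widens, with a number 2.20 log units higher from compound 2 to compound 4 (beyond the scatter) now exceeding the earlier widest step, a number 1.16 log units lower from compound 1 to compound 2 (beyond the scatter), and the order from the lowest runs acetamido, methyl, chloro, phenylsulfanyl. Nothing available explains this order, which stands here only as a ranking of four groups on one carbon.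

Phenylsulfanyl brings a sulfur and a six-membered aromatic ring together, so these compounds cannot show how much of the step belongs to each; phenyl, phenoxy or benzyl on the same carbon would separate the two. As far as these compounds go, whether the ranking would extend to an amine, a carboxylic acid or a longer chain such as butyl at this position also remains open.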